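Series notes: cytotoxicity from compound 3 to compound 4

A few compounds are considered here, and "the series" means these few. Any claim that something is new, unique, unknown or untested is made for them only; others in the source may bear on it.

In an ADME assay on BJ cells (Homo sapiens) for cytotoxicity, read by CellTiter-Glo and resazurin assay, with a stated time of 72 h (a lower number here means that less compound is needed, a higher number that more compound is needed for the effect), compound 3 `CCOC(=O)CCCCCOc1cccc(CN(C(=O)c2ccc(-c3ccc4[nH]ccc4c3)cc2)C(C)C)c1` gives > 26000 nM, which is a limit of the assay and not a number. Compound 2 `CCOC(=O)CCCCCOc1cccc(CN(C(=O)c2ccc(-c3cccc(N(C)C)c3)cc2)C(C)C)c1` also reaches only a limit in this assay, namely > 26000 nM. Compound 1 `CC(C)N(Cc1cccc(OCCCCCC(=O)O)c1)C(=O)c1ccc(-c2cccc(OC(F)(F)F)c2)cc1` likewise ends at a limit of > 26000 nM. All three values shown sit at the limit of > 26000 nM in this assay, at which 3 of the 3 values shown sit, so compound 3 stands at the shared limit and cannot be ordered against the other two. Within the data shown here, the only measured step between neighbours, a step that the two limits leave unreadable from compound 2 to compound 3, runs from one limit to another and gives no readable size.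

Compound 4 `CCOC(=O)CCCCCOc1cccc(CN(C(=O)c2ccc(-c3cccc(OC(F)(F)F)c3)cc2)C(C)C)c1` differs from compound 3 by 3-(trifluoromethoxy)phenyl in place of 1H-indol-5-yl on an aromatic carbon. Among the measured compounds shown here, the entering group is the one carried by compound 1, which in this assay stands at > 26000 nM. No measured step has a readable size, so nothing among the numbers shown points to a change in this assay beyond the scatter; the expectation rests on every value shown sitting at the limit. The step from compound 3 to compound 4 is expected to be a step that the limit leaves unreadable from compound 3 to compound 4. Compound 4 is estimated at 30000 nM, in a range from 14000 nM to 90000 nM, and is expected to be reported again as a limit.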

Compound 4, half-maximal effective concentration: > 26000 nM
Compound 4: a limit, no number (the forecaster's own chance of this, stated with the estimate: 85%); the middle value is on the limit's open side.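

In this assay compound 4 gives > 26000 nM, a limit of the assay and not a number. Its steps from compound 1, compound 2 and compound 3 therefore cannot be read: the limit of > 26000 nM in this assay, at which 4 of the 4 values shown sit.

The compounds shown leave open whether the groups exchanged among compound 1, compound 2, compound 3 and compound 4 differ at all in this assay.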